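Methyl in place of chloro on a weak antiproliferative chalcone

This account rests on a few compounds, and the source may have more. Where it says the series, first, only, none or still open, it means among the compounds named here.

Compound 1 `COc1cc(-c2cc(C(=O)/C=C/c3ccc(Cl)cc3)nc3cc(-c4ccccc4)nn23)cc(OC)c1OC` and compound 2 `COc1ccc(-c2cc(C(=O)/C=C/c3ccc(Cl)cc3)nc3cc(-c4ccccc4)nn23)cc1OC` share a core carrying a phenyl-substituted bicyclic heteroaromatic system joined through an enone to a 4-chlorophenyl group. In a functional assay on A549 cells (Homo sapiens) for antiproliferative activity, read by MTT assay, with a stated time of 24 h (a higher number here means a weaker inhibitor, a lower number a stronger inhibitor), compound 1 gives 23800 nM, and compound 2 gives 22000 nM. For the measured compounds named here, the only step between them, a 1.1-fold lower number from compound 1 to compound 2 (0.03 log units; within the scatter), concerns the trimethoxyphenyl side of the core and leaves the two compounds indistinguishable. Compound 1 therefore holds the higher of two numbers that sit within the scatter of each other, both far from potent.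

Compound 3 `COc1cc(-c2cc(C(=O)/C=C/c3ccc(C)cc3)nc3cc(-c4ccccc4)nn23)cc(OC)c1OC` arises from compound 1 by a different alteration: methyl in place of chloro on an aromatic carbon. Going by the values given here, no measured step touches the 4-chlorophenyl end of the enone, so the single step available says nothing direct about this exchange; it shows only that a small change on the other aryl ring moved the number within the scatter. Among the compounds with values here, with no precedent for replacing a halogen by a methyl at this position, the expected step of a 1.1-fold higher number from compound 1 to compound 3 (0.04 log units; within the scatter) is taken as none beyond the scatter, with a wide allowance. For compound 3 the estimated value in this assay is 26000 nM, ranging from 10000 nM to 65000 nM.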

Compound 3, half-maximal inhibitory concentration: 20000 nM
Beside the measured number, compound 3's estimate is 1.3-fold (0.11 log units) above it; the measured number falls inside the stated range.
By their numbers in this assay, from the lowest: compounds 3, 2 and 1 (each within the scatter of the next).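

For the compounds shown here, compound 3 is the first compound here altered at the 4-chlorophenyl end of the enone, a position the earlier step between compound 1 and compound 2 did not touch. In this assay, the change from 4-chlorophenyl to 4-methylphenyl gives a 1.2-fold lower number from compound 1 to compound 3 (0.08 log units; within the scatter), so this assay does not separate chloro from methyl on this aromatic carbon, para to a large group. Each of the two single changes now seen, one at either aryl end of the molecule, therefore stays within the scatter, and no information on the reason for this accompanies the numbers.

These compounds leave open whether a group of a different kind at this place, such as an amine, a carboxylic acid or a longer alkyl chain, would move the number beyond the scatter, since chloro and methyl are the only two groups shown there. From the compounds shown here alone, it also remains open whether the same exchange of chloro for methyl would read the same way on compound 2, which carries one methoxy fewer on its other aryl ring.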